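This account rests on a few compounds, and the source may have more. Where it says the series, first, only, none or still open, it means among the compounds named here.

Measured compounds, with the read-out from a functional assay on MCF7 cells (Homo sapiens) for cytotoxicity, read by MTT assay, with a stated time of 24 h, tested at 0.64 ug/mL; on this read-out higher numbers stand for a stronger effect at the one concentration tested and lower numbers for a weaker effect:

compound 1 `Cc1ccc2oc(SCC(=O)Nc3ccc(-c4nc(-c5ccccc5)c(-c5ccccc5)n4C)cc3)nc2c1` gives 1.1%
compound 2 `CCN1CCN(CC(=O)Nc2ccc(-c3nc(-c4ccccc4)c(-c4ccccc4)n3C)cc2)CC1` gives 4.7%
compound 3 `CN(C)/C=C/N1CCN(CC(=O)Nc2ccc(-c3nc(-c4ccccc4)c(-c4ccccc4)n3C)cc2)CC1` gives 1.2%

In this assay, among the measured compounds shown here, compound 1 has the smallest of the three numbers, but no measured compound is separated from it by more than the scatter: the nearest is compound 3 and the furthest is compound 2, and the gap to each is within scatter. Compound 4 `Cn1c(-c2ccc(NC(=O)CN3CCN(c4ccccc4)CC3)cc2)nc(-c2ccccc2)c1-c1ccccc1` has not yet been measured. It differs from compound 1 in one place: 4-phenylpiperazin-1-yl in place of (5-methyl-1,3-benzoxazol-2-yl)sulfanyl on a saturated chain carbon bound to a carbonyl carbon.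

The two measured steps that bear on this change both replace the same leaving group at the same place with a piperazinyl group carrying a different substituent on the ring nitrogen. Those steps were a number 3.6 percentage points higher from compound 1 to compound 2 (within the scatter) and a number 0.1 percentage points higher from compound 1 to compound 3 (within the scatter), each within scatter. The step between the two piperazine compounds, a number 3.5 percentage points lower from compound 2 to compound 3 (within the scatter), was likewise within scatter. Nothing among the three measured compounds therefore points to a step beyond the scatter when a phenyl is carried on that ring nitrogen instead of an ethyl or a 2-(dimethylamino)ethenyl group.

For compound 4 the expected result in this assay is 3%, with a range of 0% to 12%. This estimate means a step of a number 1.9 percentage points higher from compound 1 to compound 4 (within the scatter), expected to stay within the scatter.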

Compound 4, a percentage reported as activity, at one concentration (the size of the read-out at that concentration, not a potency): 12.1%
Estimate against measurement, compound 4: 9.1 percentage points below; measured number above the stated range.
By their numbers in this assay, from the lowest: compounds 1, 3, 2 and 4 (each within the scatter of the next, the first and the last beyond it).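

Among the compounds shown here, at the saturated chain carbon bound to a carbonyl carbon, a number 11 percentage points higher from compound 1 to compound 4 (beyond the scatter) is the only step from compound 1 in this assay that leaves the scatter, so the replacement of (5-methyl-1,3-benzoxazol-2-yl)sulfanyl by a piperazinyl group no longer reads as neutral in every case, and what the piperazine carries now counts. On the amine nitrogen in the ring, the comparison divides: phenyl in place of 2-(dimethylamino)ethenyl gives a number 10.9 percentage points higher from compound 3 to compound 4 (beyond the scatter) and clears the scatter, while phenyl in place of ethyl gives a number 7.4 percentage points higher from compound 2 to compound 4 (within the scatter) and does not, so compound 4 cannot be set apart from compound 2 on this read-out. No supporting data bear on why the phenyl compound behaves this way.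

The compounds shown leave open whether the step needs a phenyl bound directly to the ring nitrogen or would hold with a benzyl group there, and whether a chlorine or a methoxy group on that phenyl would move the number further. All of these readings come from a single concentration, so they describe the size of the effect at that concentration and say nothing about potency.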